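A few compounds are considered here, and "the series" means these few. Any claim that something is new, unique, unknown or untested is made for them only; others in the source may bear on it.

Compound 1 `O=C(N/N=C/c1cccc(Br)c1)Nc1cc2c(Nc3ccc(F)c(Cl)c3)ncnc2cc1O[C@H]1CCOC1` gives 15500 nM
Compound 2 `O=C(N/N=C/c1cccc(Cl)c1Cl)Nc1cc2c(Nc3ccc(F)c(Cl)c3)ncnc2cc1O[C@H]1CCOC1` gives 27400 nM
Compound 3 `O=C(N/N=C/c1ccc(O)cc1)Nc1cc2c(Nc3ccc(F)c(Cl)c3)ncnc2cc1O[C@H]1CCOC1` gives 4890 nM

In a functional assay on PC-3 cells (Homo sapiens) for cytotoxicity, read by MTT assay, with a stated time of 72 h (on this read-out higher numbers stand for weaker inhibition and lower numbers for stronger inhibition), compound 1 sits with compound 2 at the upper end of these three numbers, and a 1.8-fold higher number from compound 1 to compound 2 (0.25 log units; within the scatter) stays within the scatter. By contrast, a 3.2-fold lower number from compound 1 to compound 3 (0.50 log units; beyond the scatter) and a 5.6-fold lower number from compound 2 to compound 3 (0.75 log units; beyond the scatter) both go beyond it.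

Compound 4 `COc1cc2ncnc(Nc3ccc(F)c(Cl)c3)c2cc1NC(=O)N/N=C/c1cccc(Br)c1` differs from compound 1 at another place, with methyl in place of oxolan-3-yl on an oxygen on an aromatic ring. All three measured steps change the group on a carbon with a double bond to nitrogen, so none bears directly on this change and the data give it no direction. They show only how far the series moved at that other place. The expectation therefore starts from compound 1 at 15500 nM and no step beyond the scatter is expected in this assay for now. On these data alone, the estimated step is a 1.1-fold lower number from compound 1 to compound 4 (0.04 log units; within the scatter) and its direction stays open. For compound 4 the estimated value is 14000 nM (expected range 5000 nM to 40000 nM).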

Compound 4, half-maximal inhibitory concentration: "not active" (no number reported)
The entry for compound 4 holds no number; there is nothing to compare the estimate with.
By their numbers in this assay, from the lowest: compound 3; then compounds 1 and 2 (each within the scatter of the next).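

In this assay, going by these compounds alone, compound 4 is recorded as "not active" with no number, so no step from compound 1 to compound 4 can be read. On these data alone, the size of the change from (oxolan-3-yl)oxy to methoxy stays open. No supporting evidence bears on this result.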